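Alkoxy chain length in a bromo-acetophenone series

The source may hold more compounds than are shown below. What is called first, only, known or untested is meant among the compounds shown, and "the series" means these compounds.

Compound 1 `CCCCCCCCCCOc1cc(OC)c(Br)cc1C(C)=O` and compound 2 `CCCCCCCCCCCCOc1cc(OC)c(Br)cc1C(C)=O` share one core; compound 3 `CCOc1cc(OC)ccc1C(C)=O` has a core whose difference from that of compound 1 is not broken down here. In a functional assay, with stated times of 30 s and 6 min, in the presence of a further agent that is not named here (a lower number here means a stronger inhibitor, a higher number a weaker inhibitor), compound 1 gives 15000000 nM, and compound 2 gives 10600000 nM, the step being a 1.4-fold lower number from compound 1 to compound 2 (0.15 log units; within the scatter) for the change (ethyl in place of hydrogen on a saturated chain carbon, ten or more bonds along the chain from an oxygen on an aromatic ring). In this assay compound 3 gives 6600000 nM. Compound 4 `CCCCOc1cc(OC)ccc1C(C)=O` is not yet measured; it is made from compound 3 by ethyl in place of hydrogen on a saturated chain carbon, two bonds along the chain from an oxygen on an aromatic ring, the same kind of change as that from compound 1 to compound 2, but at a different place on the chain, as the two descriptions of the change show. Because a 1.4-fold lower number from compound 1 to compound 2 (0.15 log units; within the scatter) lies within the scatter, a similarly small step is expected, a 1.3-fold lower number from compound 3 to compound 4 (0.12 log units; within the scatter). Compound 4 is therefore estimated at 5000000 nM in this assay.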

Compound 4, half-maximal inhibitory concentration: 15600000 nM
For compound 4 the middle estimate is 3.1-fold (0.49 log units) below the measured one; measured number above the stated range.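

In this assay the new step is a 2.4-fold higher number from compound 3 to compound 4 (0.37 log units; beyond the scatter). Set beside the earlier step, it runs in the opposite direction, and the gap between the two is real: the same change on two cores in this assay, a 1.4-fold lower number (0.15 log units; within the scatter) from compound 1 to compound 2 and a 2.4-fold higher number (0.37 log units; beyond the scatter) from compound 3 to compound 4, 3.3-fold (0.52 log units) apart, beyond the scatter of two such steps

The change therefore cannot be carried as a fixed increment from one core to the other in this series, but the data do not show whether the core or the place on the chain sets the difference, as the two steps differ in both. Still open, from the compounds shown here alone, is how the numbers run with a longer chain on the core of compound 3, such as hexyloxy. Also open, going by these compounds, is how ethoxy and butoxy behave on the core of compound 1, which would separate core from chain place.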